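This account rests on a few compounds, and the source may have more. Where it says the series, first, only, none or still open, it means among the compounds named here.

Working notes on the series. Three compounds share a core and are measured in an assay on membranes from HeLa cells for displacement of a labelled ligand from adenosine receptor A3 (Homo sapiens), read by scintillation counting, with a stated time of 180 min, tested at 1 uM; a lower number here means less inhibition, a higher number more inhibition at the concentration tested (going by the name of the read-out). Compound 1 `CC1=C(C(=O)OCC(C)C)C(c2ccoc2)NC(=O)N1` gives 16%. Compound 2 `CC1=C(C(=O)OC(C)(C)C)C(c2ccoc2)NC(=O)N1` gives 2%. Compound 3 `CC1=C(C(=O)OCC(C)C)C(c2ccoc2)NC(=S)N1` gives 1%. Compound 4 `CC1=C(C(=O)OC(C)(C)C)C(c2ccoc2)NC(=S)N1` is not yet measured in this assay.

The change from compound 1 to compound 2 is tert-butyl in place of isobutyl on an oxygen next to a carbonyl group and the step it made was a number 14 percentage points lower from compound 1 to compound 2 (beyond the scatter). The same change, (tert-butyl in place of isobutyl on an oxygen next to a carbonyl group), connects compound 3 and compound 4; its place line reads the same word for word, so this is the same change, and it occurs twice among the four compounds. Compound 1 and compound 3 differ in their cores, and the difference between the two cores is not broken down here; what the values show is that compound 1 gives 16% whereas compound 3 gives 1%.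

The first occurrence of the change lowered inhibition. Compound 3, however, already sits at the bottom of the scale, so the same change cannot take compound 4 down by a comparable amount. The step from compound 3 to compound 4 in this assay is therefore expected to be a number 1 percentage points higher from compound 3 to compound 4 (within the scatter), which is within the scatter. For compound 4, inhibition in this assay is estimated at 2%, with a range from 0% to 10%.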

Compound 4, a percentage reported as inhibition, at one concentration (the size of the read-out at that concentration, not a potency): 19%
The estimate for compound 4 lay 17 percentage points below the measured number; measured number above the stated range.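

In this assay, tert-butyl in place of isobutyl on an oxygen next to a carbonyl group gives a number 18 percentage points higher from compound 3 to compound 4 (beyond the scatter), and this step does not repeat the earlier one in direction or size: the same change on two cores in this assay, a number 14 percentage points lower (beyond the scatter) from compound 1 to compound 2 and a number 18 percentage points higher (beyond the scatter) from compound 3 to compound 4, 32 percentage points apart, beyond the scatter of two such steps. In this series, therefore, the step seen on the core of compound 1 cannot be carried over to the core of compound 3, not even as to its sign. This does not show why the two steps part, and it sets no rule for other cores, since each core contributes a single pair, read at a single concentration, so that the numbers are sizes of inhibition and not potencies.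

From the compounds shown here alone, whether the opposite directions persist with a longer chain or a benzyl group on that oxygen remains open, as does the question of which of the two cores, if either, sets the direction for other groups there. Going by these compounds, what a carboxylic acid or an amide in place of the ester would give on either core is equally open.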